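Losing the propylsulfanyl chain from compound 3

The compounds below may be only part of what the source reports. "The series", "measured", "known", "first", "only" and "open" are said of these compounds alone.

Measured in a functional assay on PC-9 cells (Homo sapiens) for inhibition, read by MTT assay, with a stated time of 72 h; on this read-out higher numbers stand for weaker inhibition and lower numbers for stronger inhibition:
compound 1 `Cc1cc(Nc2cc(-c3ccccc3)[nH]n2)n2nc(SCc3ccc(F)cc3)nc2n1`: 8110 nM
compound 2 `C=CCSc1nc2nc(C)cc(Nc3cc(-c4ccccc4)[nH]n3)n2n1`: > 50000 nM (a limit)
compound 3 `CCCSc1nc2nc(C)cc(Nc3cc(-c4ccccc4)[nH]n3)n2n1`: > 50000 nM (a limit)

Compound 3 has no number, only the limit > 50000 nM. Compound 4 `Cc1cc(Nc2cc(-c3ccccc3)[nH]n2)n2ncnc2n1` differs from it as follows: hydrogen in place of propylsulfanyl on an aromatic carbon. In words, this is hydrogen in place of propylsulfanyl on an aromatic carbon.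

Going by the values given here, the steps that bear on this are changes on the same chain: an at least 6.1-fold higher number from compound 1 to compound 2 (0.78 log units; beyond the scatter) and an at least 6.1-fold higher number from compound 1 to compound 3 (0.78 log units; beyond the scatter), both beyond the scatter. In addition, a step that the two limits leave unreadable from compound 2 to compound 3 cannot be read. None of them removes the sulfur, which leaves the comparison indirect. Among the three, only compound 1, with 4-fluorophenyl on the chain, gives a number, 8110 nM. Compound 4 lacks that group too, and no gain is expected from it.

In this assay the expected step is a number no higher from compound 3 to compound 4 (the limit leaves the size open), with no readable change and a result at the limit being likely. Compound 4 is estimated at 50000 nM, with an expected range of 15000 nM to 100000 nM.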

Compound 4, half-maximal inhibitory concentration: > 50000 nM
Compound 4 gave a limit, no number (the forecaster's own chance of this, stated with the estimate: 70%); the middle value sits exactly at the limit.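

In this assay, compound 4, with hydrogen on the aromatic carbon of the five-membered ring, gives only a limit, so removing the whole sulfur-linked chain produces no number: the limit of > 50000 nM in this assay, at which 3 of the 4 values shown sit. The steps to compound 4 from compound 2 and compound 3 cannot be read. Hydrogen in place of (4-fluorobenzyl)sulfanyl gives an at least 6.1-fold higher number from compound 1 to compound 4 (0.78 log units; beyond the scatter), so within this set a number appears only with that group.

Still open, as far as these compounds go, is how far the true values of compound 2, compound 3 and compound 4 lie past the limit. Also open, from the compounds shown here alone, is whether a plain benzylsulfanyl or an amine at this carbon would give a number.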